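Trimming the Amide of Compound 2

The compounds below may be only part of what the source reports. "The series", "measured", "known", "first", "only" and "open" are said of these compounds alone.

Of the compounds shown here, two have so far been measured in an ADME assay on microsomes from liver (Mus musculus) for metabolic stability, read by LC-MS, using NADPH, with a stated time of 30 min, tested at 0.1 uM, in the presence of a further agent that is not named here; on this read-out lower numbers stand for a less stable compound and higher numbers for a more stable compound. Compound 1 (`Nc1ccc(-c2cnc(N)c(-c3ccc(N)nc3)n2)cn1`) gives > 90%, which is a limit of the assay and not a number. Compound 2 (`Nc1ncc(-c2ccc(C(=O)N3CC(O)C3)cc2)nc1-c1ccc(C(F)(F)F)cc1`) gives > 90%, which is likewise a limit. Both readings therefore sit at the same ceiling, (the limit of > 90% in this assay, at which 2 of the 2 values shown sit), and compound 2 has no exact position on the scale. Within the data shown here, no measured pair differs in only one place, so no direct step is available as a guide.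

Compound 3 (`NC(=O)c1ccc(-c2cnc(N)c(-c3ccc(C(F)(F)F)cc3)n2)cc1`) keeps the shared core of compound 2 and changes only the amide: amino in place of 3-hydroxyazetidin-1-yl on a carbonyl carbon. In words, amino replaces 3-hydroxyazetidin-1-yl on a carbonyl carbon, turning (3-hydroxyazetidin-1-yl)carbonyl into carbamoyl.

This expectation starts from compound 2 with its reading of > 90%. In this assay, the expected step of a number at least 2 percentage points lower from compound 2 to compound 3 (that floor lies within the scatter) is none beyond the scatter, with any small shift more likely downward. The estimated value for compound 3 is 88%, with an expected range from 70% to 100%.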

Compound 3, percent of the compound remaining: > 90%
Compound 3 was reported as a limit; the forecaster's own chance of this, stated with the estimate: 50%; middle value at least 2 percentage points from the limit.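

In this assay compound 3 gives > 90%, which is a limit and not a number. Compound 2 is also reported as a limit, so no step between compound 2 and compound 3 can be read: the limit of > 90% in this assay, at which 3 of the 3 values shown sit.

The compounds shown leave open whether carbamoyl and (3-hydroxyazetidin-1-yl)carbonyl differ at all on this read-out.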